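The source may report more compounds than this note shows. Statements on the series, on what has been measured and on what is new or still open speak of the compounds shown alone.

Compound 1 `COc1ccc(F)c([C@H]2CC[C@H](COc3cccc([C@H](C4CC4)[C@H](C)C(=O)O)c3)CC2)c1` and compound 2 `COc1ccc(F)c([C@H]2CC[C@H](COc3cccc([C@H](C4CC4)[C@H](F)C(=O)O)c3)CC2)c1` share one core and differ only at the carbon that carries the acid. In a functional assay on HEK293 cells for agonist activity at Free fatty acid receptor 1 (Rattus norvegicus), read by FLIPR and calcium flux (a lower number here means that less compound is needed, a higher number that more compound is needed for the effect), compound 1 gives 0.4 nM, and in this assay compound 2 gives 163 nM. Within the data shown here, compound 2 therefore has the highest number of the two measured, and its only neighbour, compound 1, stands far lower: the step of a 410-fold higher number from compound 1 to compound 2 (2.61 log units; beyond the scatter) is the single measured step, and it shows that exchanging the methyl for fluoro on the saturated chain carbon bound to a carbonyl carbon and a saturated chain carbon costs a great deal.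

Compound 3 `COc1ccc(F)c([C@H]2CC[C@H](COc3cccc([C@H](C4CC4)[C@@](C)(F)C(=O)O)c3)CC2)c1` takes one further step: methyl in place of hydrogen on a saturated chain carbon bound to a carbonyl carbon, a fluorine atom and a saturated chain carbon. The methyl that was lost on the way to compound 2 is thus returned, while the fluorine stays. Among the measured compounds shown here, the only step that bears on it is the large step from compound 1 to compound 2, which speaks for the methyl being valuable; but no compound here carries both groups at once, so how they act together is unknown. Compound 3 is expected to recover part of that loss, with a step of a 4.1-fold lower number from compound 2 to compound 3 (0.61 log units; beyond the scatter), and its expected value in this assay is 40 nM, ranging from 5 nM to 400 nM.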

Compound 3, half-maximal effective concentration: 0.34 nM
Compound 3: middle estimate off by 120-fold (2.07 log units), on the high side; the measured number lies below the stated range.
By their numbers in this assay, from the lowest: compounds 3 and 1 (each within the scatter of the next); then compound 2.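

At the saturated chain carbon bound to a carbonyl carbon, a fluorine atom and a saturated chain carbon, adding the methyl gives a 480-fold lower number from compound 2 to compound 3 (2.68 log units; beyond the scatter) in this assay, so this small change matters greatly even with the fluorine in place. The step of a 1.2-fold lower number from compound 1 to compound 3 (0.07 log units; within the scatter) shows that, with the methyl present, the fluorine can sit on this carbon without a change beyond the scatter; the high number of compound 2 therefore goes with the hydrogen that compound 3 lacks, not with the fluorine alone. The data at hand offer no explanation for why this single methyl has so large an effect.

The compounds shown leave open whether the methyl itself can give way to another group, such as an ethyl, or whether a hydroxyl could take the place of the fluorine while the methyl stays. They also leave open how the mirror-image arrangement at this carbon would read, and whether the match of compound 1 and compound 3 would hold at the same receptor from another species.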